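From Ethylamino to Allylamino on a Shared Core

The compounds below may be only part of what the source reports. "The series", "measured", "known", "first", "only" and "open" are said of these compounds alone.

Of the compounds shown here, two with the same core have been measured in a functional assay on HL-60 cells (Homo sapiens) for cytotoxicity, read by MTT assay, with a stated time of 48 h; on this read-out higher numbers stand for weaker inhibition and lower numbers for stronger inhibition. Compound 1 (`CCNc1n[n+]([O-])c2ccccc2[n+]1[O-]`), which carries an ethylamino group, gives 9000 nM, the higher of the two numbers and so the weaker inhibition. Compound 2 (`Cc1ccc(Nc2n[n+]([O-])c3ccccc3[n+]2[O-])cc1`) gives a lower number, 1500 nM.

The next compound to be tested is compound 3 (`C=CCNc1n[n+]([O-])c2ccccc2[n+]1[O-]`), which differs from compound 1 by a single change: vinyl in place of methyl on a saturated chain carbon bound to a nitrogen on an aromatic ring. The ethylamino group of compound 1 thus becomes an allylamino group in compound 3.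

Within the data shown here, no measured pair shows this change on its own, and compound 2, at 1500 nM, differs from compound 1 in more than this one place, so it offers only a loose guide. The expected change in this assay is small, tending toward a lower number but not clearly beyond the usual scatter, and is estimated as a 1.5-fold lower number from compound 1 to compound 3 (0.18 log units; within the scatter). For compound 3 the estimated value is 6000 nM, with an expected range from 2500 nM to 14000 nM.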

Compound 3, half-maximal inhibitory concentration: 25800 nM
For compound 3 the middle estimate is 4.3-fold (0.63 log units) below the measured one; measured number outside the range, above it.
By their numbers in this assay, from the lowest: compound 2; then compound 1; then compound 3.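

In this assay, putting vinyl in place of methyl on a saturated chain carbon bound to a nitrogen on an aromatic ring gives a 2.9-fold higher number from compound 1 to compound 3 (0.46 log units; beyond the scatter) and so moves toward weaker inhibition, a modest step that lies beyond the scatter. Among these compounds, this is the first step read at this place on the shared core, and it shows that the ethylamino group cannot be exchanged for allylamino without a change in the read-out, even though the exchange brings in only one double bond outside aromatic rings and no hydrogen-bond donor or acceptor. Nothing available on these compounds bears on why the number moves in this direction.

A single step cannot separate the double bond itself from the other differences between the ethyl and allyl groups, and a propyl group, the saturated counterpart of allyl, would speak to that question. From the compounds shown here alone, it also remains open whether a longer chain, a cyclopropylmethyl group or a hydroxyl group on the ethyl chain would shift the number in the same direction on this core.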